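From 3-methoxyphenyl to 2-cyanophenyl: what to expect

The source may hold more compounds than are shown below. What is called first, only, known or untested is meant among the compounds shown, and "the series" means these compounds.

Compound 1 `Cc1nc(N2CCN(C)CC2)c2nc(-c3ccccc3C(F)(F)F)n(C3CCOCC3)c2n1` at 61%
Compound 2 `COc1ccccc1-c1nc2c(N3CCN(C)CC3)nc(C)nc2n1C1CCOCC1` at 36%
Compound 3 `COc1cccc(-c2nc3c(N4CCN(C)CC4)nc(C)nc3n2C2CCOCC2)c1` at 46%

In an ADME assay (liver) for metabolic stability, with Liver microsome (Canis lupus familiaris) as the target, read by LC-MS, using microsomes, with a stated time of 30 min, tested at 4 uM (on this read-out lower numbers stand for a less stable compound and higher numbers for a more stable compound), compound 3 stands at 46% in the middle of these numbers. The measurements show a number 10 percentage points higher from compound 2 to compound 3 (within the scatter) and also a number 15 percentage points lower from compound 1 to compound 3 (beyond the scatter) on the other side.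

The next compound is compound 4 `Cc1nc(N2CCN(C)CC2)c2nc(-c3ccccc3C#N)n(C3CCOCC3)c2n1` and it differs from compound 3 as follows: 2-cyanophenyl in place of 3-methoxyphenyl on an aromatic carbon.

Going by the values given here, no measured compound carries a nitrile, so no step measures this change directly. The nearest evidence is the other aromatic swaps at this place: a number 25 percentage points lower from compound 1 to compound 2 (beyond the scatter) and the two steps above. These steps run in both directions and stay modest, which gives no firm direction for the new group.

In this assay the expected outcome is a number 4 percentage points higher from compound 3 to compound 4 (within the scatter) and a step beyond the scatter is not expected. For compound 4 the estimated value is 50% (range 33% to 67%).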

Compound 4, percent of the compound remaining: 11%
Compound 4: the middle estimate sits 39 percentage points above what was measured, outside the stated range (below it).
By their numbers in this assay, from the lowest: compound 4; then compounds 2 and 3 (each within the scatter of the next); then compound 1.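

The earlier swaps at this place stayed modest, but this one reaches further in this assay, with a number 35 percentage points lower from compound 3 to compound 4 (beyond the scatter). Comparing the groups on the phenyl ring points the same way for cyano against methoxy, with a number 25 percentage points lower from compound 2 to compound 4 (beyond the scatter), and against trifluoromethyl, with a number 50 percentage points lower from compound 1 to compound 4 (beyond the scatter), so compound 4 is the least stable of the four. Nothing measured here accounts for this drop.

The compounds shown leave open whether a nitrile elsewhere on the phenyl ring would give as low a number. They also leave open how a chlorine atom, a primary amide or a carboxylic acid would fare in place of the nitrile.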